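Methoxy in place of hydroxy on an inactive benzamide

The source may report more compounds than this note shows. Statements on the series, on what has been measured and on what is new or still open speak of the compounds shown alone.

Compound 1 `Nc1ccccc1NC(=O)c1ccc(CNC2=NC(=O)C(c3ccccc3)N2)cc1`: in an assay on isolated protein for inhibition of protein deacetylase HDAC6 (Homo sapiens), read by fluorescence, with stated times of 3 h and 60 min (a higher number here means a weaker inhibitor, a lower number a stronger inhibitor), compound 1 gives > 20000 nM, which is a limit of the assay and not a number.
Compound 2 `Nc1cc(O)ccc1NC(=O)c1ccc(CNc2nccc(-c3cccnc3)n2)cc1`: in this assay compound 2 gives > 20000 nM, likewise a limit.
Compound 3 `CC(C)(C)OC(=O)N1C(NCc2ccc(C(=O)Nc3ccccc3N)cc2)=NC(=O)C1Cc1c[nH]c2ccccc12`: in this assay compound 3 gives > 20000 nM, again a limit.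

Compound 2 stands exactly where every value shown stands: at the limit of > 20000 nM in this assay, at which 3 of the 3 values shown sit. Going by the values given here, none of the three values is a number, so no order among the three compounds can be read, and no step between any two of them is known in size or direction.

Compound 4 `COc1ccc(NC(=O)c2ccc(CNc3nccc(-c4cccnc4)n3)cc2)c(N)c1` differs from compound 2 in one place: methyl in place of hydrogen on an oxygen on an aromatic ring. Among the compounds with values here, with no measured step to lean on, the account has only the limits themselves. The expected step from compound 2 to compound 4 is a step that the limit leaves unreadable from compound 2 to compound 4, that is, none beyond the scatter. Compound 4 is therefore estimated at 30000 nM, within 10000 nM to 100000 nM, and is expected most likely to be reported only as a limit once more.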

Compound 4, half-maximal inhibitory concentration: > 20000 nM
Compound 4 gave a limit, no number; the forecaster's own chance of this, stated with the estimate: 80%; the middle value lies beyond the limit too.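

Going by these compounds alone, compound 2 and compound 4 both give only a limit, not a number, so no step from hydroxy to methoxy can be read between them: the limit of > 20000 nM in this assay, at which 4 of the 4 values shown sit. The compounds shown leave open whether methoxy and hydroxy differ at all in this assay.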